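From 4-vinylphenyl to 3-fluoro-4-methoxyphenyl in compound 4

This account rests on a few compounds, and the source may have more. Where it says the series, first, only, none or still open, it means among the compounds named here.

Measured in a functional assay on HeLa cells (Homo sapiens) for inhibition, read by CCK-8 assay, with a stated time of 48 h; on this read-out lower numbers stand for stronger inhibition and higher numbers for weaker inhibition:
- Compound 1 `COc1cc(-c2ccnc3cc(-c4ccc(F)cc4)nn23)cc(OC)c1OC`: 5840 nM
- Compound 2 `COc1cc(-c2ccnc3cc(-c4c[nH]c5ccccc45)nn23)cc(OC)c1OC`: 195 nM
- Compound 3 `C=Cc1ccc(-c2cc3nccc(-c4cc(OC)c(OC)c(OC)c4)n3n2)cc1`: 882 nM

Compound 3 sits in the middle of these three, with its 882 nM lower than the number for compound 1 and higher than the number for compound 2. Compound 4 `COc1ccc(-c2cc3nccc(-c4cc(OC)c(OC)c(OC)c4)n3n2)cc1F` keeps the shared core and has 3-fluoro-4-methoxyphenyl in place of 4-vinylphenyl on an aromatic carbon. The closest guide is the step of a 6.6-fold lower number from compound 1 to compound 3 (0.82 log units; beyond the scatter), in which vinyl replaced fluoro on the phenyl ring. The incoming group carries fluoro again and has no vinyl, which points back towards compound 1. However, it also brings a methoxy, and no measured compound shows what a methoxy on this ring does. The steps of a 30-fold lower number from compound 1 to compound 2 (1.48 log units; beyond the scatter) and a 4.5-fold higher number from compound 2 to compound 3 (0.66 log units; beyond the scatter) show that changing this group can move the number well beyond the scatter. A modest step to a higher number is therefore expected in this assay. The expected step is a 1.9-fold higher number from compound 3 to compound 4 (0.28 log units; within the scatter). For compound 4 the estimated value is 1700 nM, with an expected range of 500 nM to 5500 nM.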

Compound 4, half-maximal inhibitory concentration: 236 nM
The estimate for compound 4 lay 7.2-fold (0.86 log units) above the measured number, outside the stated range (below it).
By their numbers in this assay, from the lowest: compounds 2 and 4 (each within the scatter of the next); then compound 3; then compound 1.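

In this assay, the step of a 3.7-fold lower number from compound 3 to compound 4 (0.57 log units; beyond the scatter) shows that 3-fluoro-4-methoxyphenyl gives a clearly lower number at this position than 4-vinylphenyl, against the direction that the fluoro of compound 1 might suggest. The step of a 1.2-fold higher number from compound 2 to compound 4 (0.08 log units; within the scatter) means that a group with one six-membered aromatic ring of carbon only gives a number that cannot be told apart from that of 1H-indol-3-yl. With a 25-fold lower number from compound 1 to compound 4 (1.39 log units; beyond the scatter) as well, a fluoro on this phenyl ring does not by itself bring a high number, since 4-fluorophenyl and 3-fluoro-4-methoxyphenyl lie far apart.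

Still open, as far as these compounds go, is whether the methoxy or the placing of the fluoro accounts for this step, and how an amine or a carboxylic acid on this ring would read. No other measurement here bears on why these groups differ.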